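This account rests on a few compounds, and the source may have more. Where it says the series, first, only, none or still open, it means among the compounds named here.

Compound 1 (`O=C(/C=C\c1ccc(O)cc1)N1N=C(c2ccncc2)OC1c1c[nH]c2ccccc12`) stands in an ADME assay on HeLa cells (Homo sapiens) for cytotoxicity, read by MTT assay, with a stated time of 72 h (a lower number here means a stronger inhibitor of growth, a higher number a weaker inhibitor of growth), at > 30 ug/mL and this is a limit, not a number. Compound 2 (`O=C(/C=C\c1ccc([N+](=O)[O-])cc1)N1N=C(c2ccncc2)OC1c1c[nH]c2ccccc12`) also gives only a limit at > 30 ug/mL in this assay and no number. Among the measured compounds shown here, the one measured step bearing on the change is a step that the two limits leave unreadable from compound 1 to compound 2 and it gives no size to carry over. For the measured compounds named here, the series so far is the limit of > 30 ug/mL in this assay, at which 2 of the 2 values shown sit, without a single number. Compound 3 (`Cc1ccc(/C=C\C(=O)N2N=C(c3ccncc3)OC2c2c[nH]c3ccccc23)cc1`) differs from compound 1 by methyl in place of hydroxy on an aromatic carbon on the same core. The expected step is a number no higher from compound 1 to compound 3 (the limit leaves the size open) with no direction expected beyond the scatter. For compound 3 the estimate is 30 ug/mL with an expected range from 12 ug/mL to 60 ug/mL and a report of only a limit is the likeliest outcome.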

Compound 3, concentration for 50% growth inhibition: > 30 ug/mL
Compound 3 gave a limit, no number (the forecaster's own chance of this, stated with the estimate: 70%); the middle value sits exactly at the limit.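

No step to compound 3 from compound 1 or compound 2 can be read in this assay, since each value is a limit and not a number: the limit of > 30 ug/mL in this assay, at which 3 of the 3 values shown sit.

The compounds shown leave open whether hydroxy, nitro or methyl on the aromatic carbon makes any difference to growth inhibition.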